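The compounds below may be only part of what the source reports. "The series", "measured", "known", "first", "only" and "open" are said of these compounds alone.

In a physicochemical assay for pharmacokinetics, read by HPLC, at pH 7.5, tested at 250 uM (a lower number here means that the compound disappears faster, a higher number that the compound lasts longer), compound 1 `COc1ccc2c(c1)CC(CN(C)C)C2=O` gives 0.75 h, while compound 2 `COc1ccc2c(c1)C(=O)C(CN(C)C)C2` gives 0.2 h. Compound 2 therefore holds the lower of the two numbers, and the gap between them lies beyond the scatter. Compound 3 `COc1cc2c(cc1OC)C(=O)C(CN(C)C)C2` differs from compound 2 by one change, methoxy in place of hydrogen on an aromatic carbon, ortho to a methoxy group, meta to a fused ring and para to a fused ring. Among the measured compounds shown here, no measured pair shows this change directly, so any forecast rests on thin evidence. The entering methoxy takes the place where compound 1, at 0.75 h, carries its own methoxy, so a longer half-life is expected in this assay. The expected change is a 3.0-fold higher number from compound 2 to compound 3 (0.48 log units; beyond the scatter), a rise probably beyond the scatter. For compound 3 the estimated half-life is 0.6 h, within an expected range of 0.25 h to 1.5 h.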

Compound 3, half-life: 0.933 h
Compound 3: the middle estimate sits 1.6-fold (0.19 log units) below what was measured; the measured number falls inside the stated range.
By their numbers in this assay, from the lowest: compound 2; then compounds 1 and 3 (each within the scatter of the next).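

In this assay, among the compounds shown here, this is the first direct reading of methoxy in place of hydrogen on an aromatic carbon, ortho to a methoxy group, meta to a fused ring and para to a fused ring: the change gives a 4.7-fold higher number from compound 2 to compound 3 (0.67 log units; beyond the scatter). The same kind of change at the other methoxy place on the shared core gives a 1.2-fold higher number from compound 1 to compound 3 (0.09 log units; within the scatter), so a methoxy group at this position goes with a step beyond the scatter, whereas the step at the other place stays within it. Nothing available accounts for this difference between the two steps.

The compounds shown leave open whether the step depends on methoxy itself, since no other group, such as ethoxy, hydroxy or a fluorine atom, appears at this carbon. They also leave open whether it would persist if a longer chain replaced the dimethylaminomethyl side chain.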